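Cytotoxicity notes: aryl hydrazone series, step to pyridyl

A few compounds are considered here, and "the series" means these few. Any claim that something is new, unique, unknown or untested is made for them only; others in the source may bear on it.

Measured so far in an ADME assay on THP-1 cells (Homo sapiens) for cytotoxicity; on this read-out lower numbers stand for stronger inhibition and higher numbers for weaker inhibition:
Compound 1, `COc1ccccc1-c1nnc(-c2ccc(C(=O)N/N=C/c3cccc(F)c3)cc2)o1`, gives 353000 nM.
Compound 2, `COc1ccccc1-c1nnc(-c2ccc(C(=O)N/N=C/c3cccc([N+](=O)[O-])c3)cc2)o1`, gives 119000 nM.
Compound 3, `COc1ccccc1-c1nnc(-c2ccc(C(=O)N/N=C/c3ccc(O)cc3O)cc2)o1`, gives 104000 nM.

Compound 3 has the lowest number of the three in this assay, though its gap to compound 2 is within the scatter, so no order between compound 2 and compound 3 can be claimed; only compound 1 stands clearly apart, as a 3.4-fold lower number from compound 1 to compound 3 (0.53 log units; beyond the scatter) and a 1.1-fold lower number from compound 2 to compound 3 (0.06 log units; within the scatter) show.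

Compound 4, `COc1ccccc1-c1nnc(-c2ccc(C(=O)N/N=C/c3ccccn3)cc2)o1`, is not yet measured. It differs from compound 3 at the hydrazone carbon: pyridin-2-yl in place of 2,4-dihydroxyphenyl on a carbon with a double bond to nitrogen. For the measured compounds named here, the steps that bear on this change are the two that swap the aryl group at the same carbon, a 3.4-fold lower number from compound 1 to compound 3 (0.53 log units; beyond the scatter) and a 1.1-fold lower number from compound 2 to compound 3 (0.06 log units; within the scatter), together with a 3.0-fold lower number from compound 1 to compound 2 (0.47 log units; beyond the scatter). Going by the values given here, all changes at this position so far moved the number within a modest band, and no measured compound carries a pyridin-2-yl group, so no direct precedent exists. The expectation is a step of modest size at most, if anything toward a higher number, roughly a 1.7-fold higher number from compound 3 to compound 4 (0.24 log units; within the scatter). Compound 4 is therefore estimated at 180000 nM, with a range from 70000 nM to 450000 nM.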

Compound 4, half-maximal inhibitory concentration: 67000 nM
Compound 4: the middle estimate sits 2.7-fold (0.43 log units) above what was measured; measured number below the stated range.
By their numbers in this assay, from the lowest: compounds 4, 3 and 2 (each within the scatter of the next); then compound 1.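

In this assay, pyridin-2-yl brings a ring with a hetero atom to the carbon with a double bond to nitrogen, and compound 4 cannot be separated from the two nearest compounds, with a 1.6-fold lower number from compound 3 to compound 4 (0.19 log units; within the scatter) and a 1.8-fold lower number from compound 2 to compound 4 (0.25 log units; within the scatter). Compound 4 carries 0 hydrogen-bond donors in the entering group against 2 in the 2,4-dihydroxyphenyl group of compound 3, so among these compounds the hydroxy groups are not needed for a number in this range, while a 5.3-fold lower number from compound 1 to compound 4 (0.72 log units; beyond the scatter) is the widest step yet at this carbon and leaves the 3-fluorophenyl compound as the only one set apart. No measurement on hand explains why the 3-fluorophenyl compound stands apart or why pyridin-2-yl falls with the 2,4-dihydroxyphenyl and 3-nitrophenyl compounds.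

Still open, from the compounds shown here alone, is whether the ring nitrogen of pyridin-2-yl matters at all, as an unsubstituted phenyl or a pyridin-4-yl group at this carbon could fall with compound 4 or with compound 1. Also open, going by these compounds, is how a carboxylic acid or an amine on this aryl group would behave, and whether any of these steps carry over to a different core.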